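Swapping dimethylamino for (pyridin-2-yl)amino in a cytotoxic pair

A few compounds are considered here, and "the series" means these few. Any claim that something is new, unique, unknown or untested is made for them only; others in the source may bear on it.

In a functional assay on P388 cells (Mus musculus) for cytotoxicity, with a stated time of 48 h (on this read-out higher numbers stand for weaker inhibition and lower numbers for stronger inhibition), compound 1 (`Cc1cc(-c2c(F)cc3c(=O)ccn(C4CC4)c3c2F)cc(C)n1`) gives 9700 nM and compound 2 (`Cc1cc(-c2c(F)cc3/c(=N/N(C)C)ccn(C4CC4)c3c2F)cc(C)n1`) gives 270 nM as its value, the lower of the two numbers and so the stronger inhibition, by a margin beyond the usual scatter. Compound 3 (`Cc1cc(-c2c(F)cc3/c(=N/Nc4ccccn4)ccn(C4CC4)c3c2F)cc(C)n1`) has (pyridin-2-yl)amino in place of dimethylamino on a double-bonded nitrogen and is still unmeasured. For the measured compounds named here, no measured step shows what such a swap does, so only a modest change is expected: the expected step of a 2.3-fold lower number from compound 2 to compound 3 (0.35 log units; beyond the scatter) in this assay points towards stronger inhibition and may stay within the scatter. The estimated value for compound 3 is 120 nM (expected range 20 nM to 700 nM).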

Compound 3, half-maximal inhibitory concentration: 1000 nM
Estimate against measurement, compound 3: 8.3-fold (0.92 log units) below, and the stated range ends below it.
By their numbers in this assay, from the lowest: compound 2; then compound 3; then compound 1.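

In this assay, the group on the double-bonded nitrogen clearly affects the read-out: (pyridin-2-yl)amino in place of dimethylamino gives a 3.7-fold higher number from compound 2 to compound 3 (0.57 log units; beyond the scatter), which means weaker inhibition. This position therefore does not treat the two groups alike, and the one carrying an aromatic ring gives the weaker inhibition of this pair. No accompanying measurement explains the step. The two groups differ in both a ring and an amino hydrogen, and these compounds cannot separate the two changes. Phenylamino or methylamino at this position would help to pull them apart.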